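Benzotriazole-type acyl urea versus hydroxyurea on the benzylamide

The source may report more compounds than this note shows. Statements on the series, on what has been measured and on what is new or still open speak of the compounds shown alone.

Measured compounds in a functional assay on MIA PaCa-2 cells (Homo sapiens) for inhibition; on this read-out lower numbers stand for stronger inhibition and higher numbers for weaker inhibition:
- compound 1 `CCC(C)C(NC(=O)n1nnc2ccccc21)C(=O)NC(c1ccccc1)c1ccccc1`: 69300 nM
- compound 2 `CCC(C)C(NC(=O)n1nnc2ccccc21)C(=O)NC1CCCCC1`: 40200 nM
- compound 3 `CCC(C)C(NC(=O)NO)C(=O)NCc1ccccc1`: only a limit, > 100000 nM

Among the compounds with values here, compound 3 sits at the limit of this assay and gives no number; it is the one value of the three that lies there (the limit of > 100000 nM in this assay, at which 1 of the 3 values shown sits). Compound 1 and compound 2 give numbers, both weak, and the two of them lie within the usual scatter of each other.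

Compound 4 `CCC(C)C(NC(=O)n1nnc2ccccc21)C(=O)NCc1ccccc1` is not yet measured. It differs from compound 3 by a group of 9 heavy atoms (6 carbon, 3 nitrogen; one five-membered aromatic ring with 3 hetero atoms, one six-membered aromatic ring of carbon only) in place of a group of 2 heavy atoms (1 nitrogen, 1 oxygen; no ring), on a carbonyl carbon; in words, a group of 9 heavy atoms (6 carbon, 3 nitrogen; one five-membered aromatic ring with 3 hetero atoms, one six-membered aromatic ring of carbon only) in place of a group of 2 heavy atoms (1 nitrogen, 1 oxygen; no ring), on a carbonyl carbon. Within the data shown here, no measured pair shows this change alone. The same entering group is present in compound 1 and compound 2, which do return numbers in this assay, so a step out of the limit toward weak but measurable inhibition is expected, of the size an at least 2.0-fold lower number from compound 3 to compound 4 (0.30 log units; that floor lies within the scatter). For compound 4 the expected value in this assay is 50000 nM, within 20000 nM to 120000 nM.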

Compound 4, half-maximal inhibitory concentration: > 100000 nM
Compound 4: no number, only a limit; the forecaster's own chance of this, stated with the estimate: 30%; middle value at least 2.0-fold (0.30 log units) from the limit.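

In this assay compound 4 sits at a limit of the assay, > 100000 nM, and gives no number, so on the benzylamide the group of 9 heavy atoms does not by itself bring the series to a measurable value: the limit of > 100000 nM in this assay, at which 2 of the 4 values shown sit.

With that group held constant, the amide side now counts: benzyl in place of cyclohexyl gives an at least 2.4-fold higher number from compound 2 to compound 4 (0.39 log units; beyond the scatter). Hydrogen in place of phenyl gives an at least 1.4-fold higher number from compound 1 to compound 4 (0.15 log units; that floor lies within the scatter), which does not separate those two compounds, and the step from the hydroxyamino compound cannot be read, as both of its ends are limits.

From the compounds shown here alone, how the hydroxyamino group and the entering group compare on the benzylamide therefore stays open. Also open, going by these compounds, is whether a phenethyl group or a longer chain in place of benzyl on the amide-type nitrogen would return a number in this assay.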